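Extending the thioester chain on a shared pyrazole-amide core

The source may report more compounds than this note shows. Statements on the series, on what has been measured and on what is new or still open speak of the compounds shown alone.

Of the compounds shown here, three built on one shared core have been measured in an ADME assay on HEK293 cells (Homo sapiens) for inhibition, read by MTT assay, with a stated time of 96 h; a higher number here means a weaker inhibitor of growth, a lower number a stronger inhibitor of growth. Compound 1 `C=CCOC(=O)SCCCCCCNC(=O)c1cc(-c2ccncc2)n[nH]1` gives 27500 nM in this assay. Compound 2 `O=C(OCc1ccccc1)SCCCCCCNC(=O)c1cc(-c2ccncc2)n[nH]1` gives 19700 nM. Compound 3 `CC(=O)SCCCCCCNC(=O)c1cc(-c2ccncc2)n[nH]1` reaches only the upper limit of this assay, > 50000 nM, so no number is known for it. The step of a 1.4-fold lower number from compound 1 to compound 2 (0.14 log units; within the scatter) is small. By contrast, an at least 1.8-fold higher number from compound 1 to compound 3 (0.25 log units; that floor lies within the scatter) and an at least 2.5-fold higher number from compound 2 to compound 3 (0.40 log units; beyond the scatter) both run upward, the second beyond the scatter, because the limit of > 50000 nM in this assay, at which 1 of the 3 values shown sits, caps what compound 3 can show.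

Compound 4 `CCCC(=O)SCCCCCCNC(=O)c1cc(-c2ccncc2)n[nH]1` is the next compound. It differs from compound 3 in one place: ethyl in place of hydrogen on a saturated chain carbon bound to a carbonyl carbon. The measured steps all touch the carbonyl end of the chain, where compound 3 carries the smallest group and stands at the limit. None of them tests ethyl in place of hydrogen at this position, so the direction of the coming step is uncertain. Since compound 3 is only a limit, the expected number for compound 4 is near that limit, with an at least 1.1-fold lower number from compound 3 to compound 4 (0.04 log units; that floor lies within the scatter) as the estimated step. Compound 4 is expected to give about 45000 nM, within a range from 18000 nM to 110000 nM.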

Compound 4, concentration for 50% growth inhibition: > 50000 nM
Compound 4: a limit, no number; the forecaster's own chance of this, stated with the estimate: 50%; middle value at least 1.1-fold (0.04 log units) from the limit.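

In this assay compound 4 gives > 50000 nM, which is a limit and not a number, so ethyl in place of hydrogen on this carbon does not bring the compound to a readable value. Set against the compounds that do have numbers, propyl in place of benzyloxy on the carbonyl carbon gives an at least 2.5-fold higher number from compound 2 to compound 4 (0.40 log units; beyond the scatter), while propyl in place of allyloxy gives an at least 1.8-fold higher number from compound 1 to compound 4 (0.25 log units; that floor lies within the scatter), so among the four compounds shown, both with a plain alkyl chain on the carbonyl carbon sit at the limit, and both with allyloxy or benzyloxy there give a number. The step from methyl to propyl itself cannot be read, because compound 3 and compound 4 both stop at the same ceiling: the limit of > 50000 nM in this assay, at which 2 of the 4 values shown sit.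

Going by these compounds, whether ethyl at this position strengthens or weakens growth inhibition therefore stays open, as neither compound has a number to compare. Also open, on these data alone, is whether a longer chain, such as octyl, or an amine on the carbonyl carbon would give a readable value in this assay.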